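Furan exchange on the chloro compound of the series

This account rests on a few compounds, and the source may have more. Where it says the series, first, only, none or still open, it means among the compounds named here.

Compound 1 `OC[C@H]1O[C@@H](n2cc(F)c3c(-c4ccco4)ncnc32)[C@H](O)[C@@H]1O` gives 5 nM
Compound 2 `OC[C@H]1O[C@@H](n2cc(F)c3c(-c4ccoc4)ncnc32)[C@H](O)[C@@H]1O` gives 5 nM
Compound 3 `OC[C@H]1O[C@@H](n2cc(Cl)c3c(-c4ccco4)ncnc32)[C@H](O)[C@@H]1O` gives > 10000 nM as a limit
Compound 4 `OC[C@H]1O[C@@H](n2cc(Cl)c3c(-c4ccoc4)ncnc32)[C@H](O)[C@@H]1O` is not yet measured

In a functional assay on DU-145 cells (Homo sapiens), read by sulforhodamine B assay, with a stated time of 5 days (on this read-out lower numbers stand for stronger inhibition of growth and higher numbers for weaker inhibition of growth), compound 3 stands at a limit (> 10000 nM) and has no number. Furan-3-yl now takes the place of furan-2-yl on an aromatic carbon (furan-3-yl in place of furan-2-yl on an aromatic carbon) with the rest of the structure unchanged. The same exchange on the fluoro compounds (no change at the digits printed from compound 1 to compound 2 (within the scatter)) lay within the scatter. The exchange of fluoro for chloro (an at least 2000-fold higher number from compound 1 to compound 3 (3.30 log units; beyond the scatter)) was large, so the fluoro result may not carry over to the chloro compounds. The step expected in this assay is therefore none beyond the scatter (a number no higher from compound 3 to compound 4 (the limit leaves the size open)) though with wide uncertainty. Compound 4 is estimated at 10000 nM with an expected range from 300 nM to 30000 nM and may again give only a limit.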

Compound 4, concentration for 50% growth inhibition: 54 nM
Beside the measured number, compound 4's estimate is 190-fold (2.27 log units) above it, outside the stated range (below it).
By their numbers in this assay, from the lowest: compounds 1 and 2 (each within the scatter of the next); then compound 4. At a limit, above all of these: compound 3.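

Furan-3-yl in place of furan-2-yl gives an at least 180-fold lower number from compound 3 to compound 4 (2.26 log units; beyond the scatter) on the chloro core, so the furan attachment matters there, although it made no difference on the fluoro core: (the same change on two cores in this assay, no change at the digits printed (within the scatter) from compound 1 to compound 2 and an at least 180-fold lower number (2.26 log units; beyond the scatter) from compound 3 to compound 4, at least 180-fold (2.26 log units) apart, beyond the scatter of two such steps). Chloro in place of fluoro gives an 11-fold higher number from compound 2 to compound 4 (1.03 log units; beyond the scatter) with furan-3-yl, a smaller penalty than with furan-2-yl: (the same change on two cores in this assay, an at least 2000-fold higher number (3.30 log units; beyond the scatter) from compound 1 to compound 3 and an 11-fold higher number (1.03 log units; beyond the scatter) from compound 2 to compound 4, at least 180-fold (2.26 log units) apart, beyond the scatter of two such steps). The halogen and the furan attachment therefore do not act independently in these four compounds.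

Compound 3 gives only a limit (> 10000 nM), which leaves the size of its steps open. From the compounds shown here alone, whether bromo or methyl in place of chloro would follow the fluoro or the chloro pattern also remains open.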